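The compounds below may be only part of what the source reports. "The series", "measured", "known", "first", "only" and "open" are said of these compounds alone.

In a functional assay on WRL68 cells (Homo sapiens) for cytotoxicity, read by colony formation (on this read-out higher numbers stand for weaker inhibition and lower numbers for stronger inhibition), two compounds have been measured so far. Compound 1, `COC(=O)C1=CO[C@@H](O[C@@H]2O[C@H](COC(c3ccccc3)(c3ccccc3)c3ccccc3)[C@@H](OC(=O)O)[C@H](OC(C)=O)[C@H]2OC(C)=O)[C@@H]2[C@@H](C)[C@@H](OC(C)=O)C[C@H]12`, gives 1.86 ug/mL, and compound 2, `CCC(=O)OC[C@H]1O[C@@H](O[C@@H]2OC=C(C(=O)OC)[C@H]3C[C@H](OC(C)=O)[C@H](C)[C@@H]23)[C@H](OC(C)=O)[C@@H](OC(C)=O)[C@@H]1OC(C)=O`, gives 8.4 ug/mL. Compound 2 therefore holds the higher of the two numbers, meaning the weaker inhibition, and the gap between them lies beyond the usual scatter. These two compounds differ in more than one place, so their gap cannot be assigned to any single group.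

Compound 3, `COC(=O)C1=CO[C@@H](O[C@@H]2O[C@H](COC(=O)C=C(C)C)[C@@H](OC(C)=O)[C@H](OC(C)=O)[C@H]2OC(C)=O)[C@@H]2[C@@H](C)[C@@H](OC(C)=O)C[C@H]12`, has not yet been measured. It departs from compound 2 in one place only: 2-methylprop-1-en-1-yl in place of ethyl on a carbonyl carbon. In words, 2-methylprop-1-en-1-yl stands in place of ethyl on a carbonyl carbon, and the rest of the molecule is unchanged. For the measured compounds named here, no measured pair shows what this exchange does in this assay, so the expectation stays cautious. The expected 1.4-fold lower number from compound 2 to compound 3 (0.15 log units; within the scatter) is small, leans toward a lower number and stays within the scatter. The estimated value for compound 3 is 6 ug/mL, expected to fall between 2.5 ug/mL and 15 ug/mL.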

Compound 3, half-maximal inhibitory concentration: 3.86 ug/mL
Compound 3: middle estimate off by 1.6-fold (0.19 log units), on the high side, and the stated range covers the measured number.
By their numbers in this assay, from the lowest: compound 1; then compound 3; then compound 2.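

In this assay, for the compounds shown here, the exchange of ethyl for 2-methylprop-1-en-1-yl on a carbonyl carbon gives a 2.2-fold lower number from compound 2 to compound 3 (0.34 log units; beyond the scatter) and is the first single-place change that can be read in this set. It shows that this position responds to the group on the carbonyl carbon: moving from propanoyloxy to ((2-methylprop-1-en-1-yl)carbonyl)oxy goes with stronger inhibition, by a modest step that lies beyond the scatter. The data shown offer no measurement that would explain this step.

The change adds carbons and a double bond at once, and this single pair cannot separate the two, so a saturated 2-methylpropyl group on the same carbonyl carbon would be the direct comparison. On these data alone, how a phenyl ring, an amine or a longer chain in that place would read in this assay remains open, as does the source of the gap between compound 1 and the other two compounds, since compound 1 differs from them in more than one place.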